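Changing the Sulfonyl Aryl Group on an Ethyl-Bearing Core

The source may report more compounds than this note shows. Statements on the series, on what has been measured and on what is new or still open speak of the compounds shown alone.

Three measured compounds share one core and differ at two places. In a functional assay on HeLa cells (Homo sapiens) for antiproliferative activity, read by MTT assay, with a stated time of 72 h (on this read-out higher numbers stand for weaker inhibition and lower numbers for stronger inhibition), compound 1 `N=C(NS(=O)(=O)c1ccc(Cl)cc1)N1CCN(c2cc3c(cc2F)c(=O)c(C(=O)O)cn3C2CC2)CC1` gives 32 nM. Compound 2 `N=C(NS(=O)(=O)c1ccccc1C(F)(F)F)N1CCN(c2cc3c(cc2F)c(=O)c(C(=O)O)cn3C2CC2)CC1` gives 32 nM in this assay, and compound 3 `CCn1cc(C(=O)O)c(=O)c2cc(F)c(N3CCN(C(=N)NS(=O)(=O)c4ccccc4C(F)(F)F)CC3)cc21` gives 32 nM in this assay.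

Compound 1 differs from compound 2 only by 4-chlorophenyl in place of 2-(trifluoromethyl)phenyl on a sulfonyl sulfur, and this change gives no change at the digits printed from compound 2 to compound 1 (within the scatter). Compound 3 differs from compound 2 at the core by ethyl in place of cyclopropyl on an aromatic nitrogen, and here this assay shows no change at the digits printed from compound 2 to compound 3 (within the scatter). Compound 3 thus stands level with compounds 1 and 2 at the digits given.

Compound 4 `CCn1cc(C(=O)O)c(=O)c2cc(F)c(N3CCN(C(=N)NS(=O)(=O)c4ccc(Cl)cc4)CC3)cc21` has not yet been measured. Compound 4 differs from compound 3 by 4-chlorophenyl in place of 2-(trifluoromethyl)phenyl on a sulfonyl sulfur. This is the same change that separates compound 2 from compound 1, made at a place described in identical words, so it occurs twice among these four compounds; the cores of the two pairs differ only as already told for compound 2 and compound 3.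

For compound 4 the expected step is no change at the digits printed from compound 3 to compound 4 (within the scatter), which rests on compound 3 giving 32 nM and on the earlier step being no change at the digits printed from compound 2 to compound 1 (within the scatter). Compound 4 is therefore estimated at 32 nM in this assay, with a plausible range from 16 nM to 64 nM.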

Compound 4, half-maximal inhibitory concentration: 32 nM
Beside the measured number, compound 4's estimate shows no gap at the digits printed; measured number inside the range.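

In this assay, placing 4-chlorophenyl for 2-(trifluoromethyl)phenyl on the sulfonyl sulfur of the ethyl-bearing core gives no change at the digits printed from compound 3 to compound 4 (within the scatter), and this reads the same as the earlier step on the cyclopropyl-bearing core: the same change on two cores in this assay, no change at the digits printed (within the scatter) from compound 2 to compound 1 and no change at the digits printed (within the scatter) from compound 3 to compound 4, 1.0-fold (0.00 log units) apart, within the scatter of two such steps Ethyl in place of cyclopropyl on the aromatic nitrogen, now with 4-chlorophenyl on the sulfonyl sulfur, gives no change at the digits printed from compound 1 to compound 4 (within the scatter), which likewise agrees with the earlier step: the same change on two cores in this assay, no change at the digits printed (within the scatter) from compound 2 to compound 3 and no change at the digits printed (within the scatter) from compound 1 to compound 4, 1.0-fold (0.00 log units) apart, within the scatter of two such steps This shows that, among these four compounds, each change carries from one core to the other without a detectable difference, but as no step here lies beyond the scatter, it does not show that a change with a measurable effect would carry across these cores in the same way.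

The compounds shown leave open whether this agreement would hold for other groups on the sulfonyl sulfur, such as an unsubstituted phenyl or a naphthyl, or for other groups on the aromatic nitrogen, such as a methyl or a longer chain like butyl. They also leave open how the series would read in this assay with an ester or an amide in place of the carboxylic acid.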